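From Aryl Amide to Cyclic Urea on a Shared Core

The source may report more compounds than this note shows. Statements on the series, on what has been measured and on what is new or still open speak of the compounds shown alone.

Compound 1 `CC1CCC(C(=O)N2CC(c3nc(-c4cccc(Cl)c4)no3)C2)CC1`: in an assay on HEK293 cells for negative allosteric modulation of metabotropic glutamate receptor 5 (Homo sapiens), read by FLIPR (on this read-out higher numbers stand for weaker inhibition and lower numbers for stronger inhibition), compound 1 gives > 10000 nM, a limit of the assay.
Compound 2 `O=C(N1CCCCC1)N1CC(c2nc(-c3cccc(Cl)c3)no2)C1`: in this assay compound 2 gives > 10000 nM, also a limit.
Compound 3 `O=C(c1ccc(F)cc1)N1CC(c2nc(-c3cccc(Cl)c3)no2)C1`: in this assay compound 3 gives 4000 nM.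

Going by the values given here, compound 3 thus holds the only number among the three; the others sit at the limit of > 10000 nM in this assay, at which 2 of the 3 values shown sit. Compound 4 `CC1CCN(C(=O)N2CC(c3nc(-c4cccc(Cl)c4)no3)C2)C1` differs from compound 3 by 3-methylpyrrolidin-1-yl in place of 4-fluorophenyl on a carbonyl carbon. Among the compounds with values here, the steps that bear on this are an at least 2.5-fold lower number from compound 1 to compound 3 (0.39 log units; beyond the scatter) and an at least 2.5-fold lower number from compound 2 to compound 3 (0.39 log units; beyond the scatter), both favouring the aryl group, while a step that the two limits leave unreadable from compound 1 to compound 2. Compound 4 reverses that move, carrying a cyclic amine as compound 2 does. Compound 4 is therefore expected to step upward, a 3.8-fold higher number from compound 3 to compound 4 (0.57 log units; beyond the scatter). Compound 4 is estimated at 15000 nM, between 4000 nM and 50000 nM, and may well be reported only as a limit.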

Compound 4, half-maximal inhibitory concentration: > 10000 nM
Compound 4: a limit, no number; the forecaster's own chance of this, stated with the estimate: 70%; the middle value lies beyond the limit too.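

Replacing 4-fluorophenyl with 3-methylpyrrolidin-1-yl on the carbonyl carbon gives an at least 2.5-fold higher number from compound 3 to compound 4 (0.39 log units; beyond the scatter), so a second cyclic amine, after piperidin-1-yl in compound 2, falls short of the aryl group at this position. In this assay compound 4 also ends at a limit, leaving compound 3 alone with a number: the limit of > 10000 nM in this assay, at which 3 of the 4 values shown sit. The steps linking compound 4 to compound 1 and compound 2 cannot be read, so these groups cannot be ordered.

The compounds shown leave open whether any non-aromatic group here can give a number. They also leave open whether unsubstituted phenyl or a pyridyl ring would match or improve on 4-fluorophenyl.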